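Aryl versus Alkyl on the Ring Nitrogen

The source may report more compounds than this note shows. Statements on the series, on what has been measured and on what is new or still open speak of the compounds shown alone.

Measured compounds:
compound 1 `COc1cccc(OC)c1N1C(=O)CSC1c1cccc(C(=O)NCCCCc2ccccc2)c1`: 95%
compound 2 `CCN1C(=O)CSC1c1cccc(C(=O)NCCCCc2ccccc2)c1`: 0%
compound 3 `COc1ccccc1N1C(=O)CSC1C(=O)NCCCCc1ccccc1`: 0%

In a functional assay on HOS-TE85 cells (Homo sapiens) for inhibition, read by CCK-8 assay, with a stated time of 72 h, tested at 1 uM (on this read-out lower numbers stand for less inhibition and higher numbers for more inhibition at the one concentration tested (going by the name of the read-out)), compound 1 gives 95%. Compound 2 gives 0% and stands level with compound 3, which gives 0%, the two together being the lowest of the three numbers. Compound 4 `CC(F)(F)c1cccc(N2C(=O)CSC2c2cccc(C(=O)NCCCCc3ccccc3)c2)c1` has not yet been measured. Its change from compound 2 is a group of 10 heavy atoms (8 carbon, 2 fluorine; one six-membered aromatic ring of carbon only) in place of a group of 2 heavy atoms (2 carbon; no ring), on an amide-type nitrogen in a ring. For the measured compounds named here, the one step that bears on it is a number 95 percentage points lower from compound 1 to compound 2 (beyond the scatter), where an aromatic ring on the ring nitrogen gave way to ethyl. Compound 4 brings an aromatic ring back to that nitrogen, though a different one, so a large rise is expected. Compound 4 is therefore expected to give 60%, within a range from 15% to 95%. The step expected for compound 4 is a number 60 percentage points higher from compound 2 to compound 4 (beyond the scatter).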

Compound 4, a percentage reported as inhibition, at one concentration (the size of the read-out at that concentration, not a potency): 93%
For compound 4 the middle estimate is 33 percentage points below the measured one; the range from low to high includes it.
By their numbers in this assay, from the lowest: compounds 2 and 3 (each within the scatter of the next); then compounds 4 and 1 (each within the scatter of the next).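

In this assay, a different aromatic ring on the amide-type nitrogen gives a number 93 percentage points higher from compound 2 to compound 4 (beyond the scatter), so the loss seen with ethyl is not tied to the 2,6-dimethoxyphenyl group alone. Exchanging one ring-bearing group for the other gives a number 2 percentage points lower from compound 1 to compound 4 (within the scatter), so at this concentration the two cannot be told apart. No supporting data explain why the ring matters here. On these data alone, whether an unsubstituted phenyl, a pyridine or a benzyl group would serve on this nitrogen remains open. A single concentration also leaves any potency difference between compound 1 and compound 4 unresolved.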